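Bromophenoxy positional isomers in the dihydrofolate reductase series

A few compounds are considered here, and "the series" means these few. Any claim that something is new, unique, unknown or untested is made for them only; others in the source may bear on it.

Within the data shown here, in an assay on isolated protein for inhibition of Dihydrofolate reductase (Homo sapiens), read by spectrophotometry, using NADPH, with stated times of 5 s and 6 min (on this read-out higher numbers stand for weaker inhibition and lower numbers for stronger inhibition), compound 1 `COc1ccc(OCCCON2C(N)=NC(N)=NC23CCOCC3)cc1` gives 11.1 nM, and compound 2 `NC1=NC2(CCOCC2)N(OCCCOc2cc(Cl)c(Cl)cc2Cl)C(N)=N1` gives 36 nM; the only measured step, a 3.2-fold higher number from compound 1 to compound 2 (0.51 log units; beyond the scatter), concerns a different aryl exchange. Compound 3 `NC1=NC2(CCOCC2)N(OCCCOc2cccc(Br)c2)C(N)=N1` is recorded as "not determined" (no result reported) in this assay, so it stands nowhere on the measured scale and its step to compound 4 `NC1=NC2(CCOCC2)N(OCCCOc2ccc(Br)cc2)C(N)=N1` cannot be anchored. The change is 4-bromophenyl in place of 3-bromophenyl on an oxygen on a saturated carbon. Among the measured compounds shown here, no measured step bears on a shift of the bromine around the ring; the two measured aryl groups merely span a modest interval. A step no larger than that interval, in either direction, is expected. Compound 4 is therefore estimated at 20 nM in this assay, with a range from 6 nM to 70 nM.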

Compound 4, half-maximal inhibitory concentration: 32.5 nM
Compound 4: middle estimate off by 1.6-fold (0.21 log units), on the low side; the measured number falls inside the stated range.
By their numbers in this assay, from the lowest: compound 1; then compounds 4 and 2 (each within the scatter of the next).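

At this place, on an oxygen on a saturated carbon, 4-bromophenyl and 2,4,5-trichlorophenyl are not separated in this assay, with a 1.1-fold lower number from compound 2 to compound 4 (0.04 log units; within the scatter) as the step. Bromo in place of methoxy on an aromatic carbon gives a 2.9-fold higher number from compound 1 to compound 4 (0.47 log units; beyond the scatter) and so leaves both halogen-bearing aryl groups on the same side of compound 1. No available evidence explains these numbers.

Going by these compounds, the step from compound 3 to compound 4 cannot be read, so the effect of moving the bromine stays open. On these data alone, how an amine or a carboxylic acid on the aromatic ring would compare also stays open.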